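Ester shortening on the quinolone core: cytotoxicity outlook

The source may hold more compounds than are shown below. What is called first, only, known or untested is meant among the compounds shown, and "the series" means these compounds.

The series shares one core, seen in compound 1 `COC(=O)c1c[nH]c2cc(OCCOc3ccccc3)c(C)cc2c1=O`, in compound 2 `CCCCc1cc2c(=O)c(C#N)c[nH]c2cc1OCCOc1ccccc1` and in compound 3 `CCCCc1cc2c(=O)c(C(=O)OCC)c[nH]c2cc1OCCOc1ccccc1`. In an ADME assay on J774 cells (Mus musculus) for cytotoxicity (on this read-out lower numbers stand for an effect already at smaller amounts and higher numbers for an effect only at larger amounts of compound), compound 1 reaches only the limit > 20000 nM, which is a limit of the assay and not a number. In this assay compound 2 likewise gives only the limit > 20000 nM. In this assay compound 3 also stops at the limit > 20000 nM; it stands on the same limit as the other two. Within the data shown here, the single one-place step between measured compounds, a step that the two limits leave unreadable from compound 2 to compound 3, cannot be sized, as the limit of > 20000 nM in this assay, at which 3 of the 3 values shown sit, shows.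

Compound 4 `CCCCc1cc2c(=O)c(C(=O)OC)c[nH]c2cc1OCCOc1ccccc1` is the next member, not yet measured. Its change from compound 3 is hydrogen in place of methyl on a saturated chain carbon bound to an oxygen next to a carbonyl group, a hydrogen in place of a methyl on a saturated chain carbon bound to an oxygen next to a carbonyl group. Among the measured compounds shown here, no measured step bears on this change, and the one step that exists is unreadable, so nothing in the numbers points either way. The expectation is that the step that the limit leaves unreadable from compound 3 to compound 4 will be nothing beyond the scatter, with the assay again most likely reporting only a limit. Compound 4 is therefore estimated at 30000 nM in this assay, within a range from 15000 nM to 100000 nM.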

Compound 4, half-maximal effective concentration: > 20000 nM
Compound 4: no number, only a limit (the forecaster's own chance of this, stated with the estimate: 85%); the middle value lies beyond the limit too.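

None of the steps from compound 1, compound 2 or compound 3 to compound 4 can be read in this assay, since all four compounds give only a limit of the assay and no number: the limit of > 20000 nM in this assay, at which 4 of the 4 values shown sit.

The compounds shown leave open where the true values of these four compounds lie beyond that limit, and whether cyano, ethoxycarbonyl and methoxycarbonyl differ at all in this assay.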